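Methyl for Fluoro on the Aromatic Ring of Compound 3

The compounds below may be only part of what the source reports. "The series", "measured", "known", "first", "only" and "open" are said of these compounds alone.

Compound 1, `O=C(C1CCCCC1)N1CC(c2nc(-c3cccc(F)c3)no2)C1`, in an assay on HEK293 cells for negative allosteric modulation of metabotropic glutamate receptor 5 (Homo sapiens), read by FLIPR; a lower number here means a stronger inhibitor, a higher number a weaker inhibitor: > 10000 nM, a limit of the assay.
Compound 2, `O=C(N1CCC(F)CC1)N1CC(c2nc(-c3cccc(Cl)c3)no2)C1`, in this assay: > 10000 nM, a limit.
Compound 3, `O=C(C1CCC(C(F)(F)F)CC1)N1CC(c2nc(-c3cccc(F)c3)no2)C1`, in this assay: > 10000 nM, a limit.

All three measured compounds sit at the same limit, (the limit of > 10000 nM in this assay, at which 3 of the 3 values shown sit), so compound 3 has no number of its own, only this limit. For the measured compounds named here, the one recorded step, a step that the two limits leave unreadable from compound 1 to compound 3, cannot be read for the same reason. Compound 4, `Cc1cccc(-c2noc(C3CN(C(=O)C4CCC(C(F)(F)F)CC4)C3)n2)c1`, differs from compound 3 by methyl in place of fluoro on an aromatic carbon. Going by the values given here, no measured step touches this part of the molecule, and the three limits give no direction. Compound 4 is therefore expected to stay near the limit, with the step that the limit leaves unreadable from compound 3 to compound 4 taken as no change beyond the scatter. The estimate for compound 4 in this assay is 15000 nM, between 3000 nM and 60000 nM.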

Compound 4, half-maximal inhibitory concentration: > 10000 nM
Compound 4: a limit, no number (the forecaster's own chance of this, stated with the estimate: 75%); the middle value lies beyond the limit too.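

Compound 3 and compound 4 both sit at a limit of the assay, so no step between them can be read: the limit of > 10000 nM in this assay, at which 4 of the 4 values shown sit.

Going by these compounds, whether methyl in place of fluoro changes inhibition at all stays open, and none of the four compounds has a number of its own.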